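The source may report more compounds than this note shows. Statements on the series, on what has been measured and on what is new or still open speak of the compounds shown alone.

Compound 1, `CCCCCCCCCCCCCC(=O)Nc1cc2c(cc1F)c(=O)c(C(=O)OCC)cn2CC`: 10400 nM
Compound 2, `CCCCCCCCCCCCCCCCCC(=O)Nc1cc2c(cc1F)c(=O)c(C(=O)OCC)cn2CC`: 37100 nM

Both compounds were tested in a functional assay on DU-145 cells (Homo sapiens) for cytotoxicity, read by MTT assay; a lower number here means a stronger inhibitor, a higher number a weaker inhibitor. Going by the values given here, compound 2 stands at the higher of the two numbers, and only compound 1 is near it: the one measured step, a 3.6-fold higher number from compound 1 to compound 2 (0.55 log units; beyond the scatter), lies beyond the scatter and goes toward a weaker inhibitor as the chain grows.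

Compound 3, `CCCCCCCCCCCC(=O)Nc1cc2c(cc1F)c(=O)c(C(=O)OCC)cn2CC`, has not been measured. Its difference from compound 2 is hydrogen in place of hexyl on a saturated chain carbon, ten or more bonds along the chain from a carbonyl carbon. This is the same kind of change as the measured step, but run the other way and further: the chain is cut rather than extended. Among the compounds with values here, the step of a 3.6-fold higher number from compound 1 to compound 2 (0.55 log units; beyond the scatter) is therefore the only measured guide, and it suggests that the number should fall as the chain shortens, so compound 3 is expected to come out lower than compound 2 by a 5.3-fold lower number from compound 2 to compound 3 (0.72 log units; beyond the scatter). Because compound 1 gives 10400 nM, compound 3 is estimated at 7000 nM, with a likely range from 2500 nM to 25000 nM.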

Compound 3, half-maximal inhibitory concentration: 12100 nM
Compound 3: the middle estimate sits 1.7-fold (0.24 log units) below what was measured; the measured number falls inside the stated range.
By their numbers in this assay, from the lowest: compounds 1 and 3 (each within the scatter of the next); then compound 2.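

Cutting the hexyl away from the saturated chain of compound 2 gives a clear change in this assay (a 3.1-fold lower number from compound 2 to compound 3 (0.49 log units; beyond the scatter)), so the weaker reading of compound 2 is now seen against two shorter chains instead of one. Taking away only an ethyl from the chain of compound 1 gives no readable change (a 1.2-fold higher number from compound 1 to compound 3 (0.07 log units; within the scatter)), which shows that the number does not shift with every change in chain length at this position: compound 1 and compound 3 stand together, and only compound 2 stands apart from them. Nothing available explains why the chain of compound 2 differs from the other two in this way.

The three compounds therefore mark out only a narrow stretch of long chains, and they do not show whether a much shorter chain, such as a propyl or a methyl in place of the long one, would bring any change in the number, or whether a still longer chain would carry the rise further. They also leave open what an amine or a carboxylic acid on the saturated chain would do in this cell assay.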